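The source may report more compounds than this note shows. Statements on the series, on what has been measured and on what is new or still open speak of the compounds shown alone.

Measured so far:
compound 1 `COc1cc(NC(=O)Nc2cc(Nc3ccc(OC)c(C)c3)ncn2)cc(OC)c1`: 13.5%
compound 2 `CCc1ccc(Nc2cc(NC(=O)Nc3c(Cl)cccc3Cl)ncn2)cc1`: 31.5%

In a functional assay on NCI-H520 cells (Homo sapiens) for inhibition, read by MTT assay, with a stated time of 48 h, tested at 10 uM (on this read-out higher numbers stand for more inhibition at the one concentration tested (going by the name of the read-out) and lower numbers for less inhibition), compound 1 gives 13.5% and stands lowest of the two numbers; compound 2 sits higher, beyond the usual scatter. Compound 3 `CCc1cccc(Nc2cc(NC(=O)Nc3cc(OC)cc(OC)c3)ncn2)c1` is not yet measured. Relative to compound 1 the change is 3-ethylphenyl in place of 4-methoxy-3-methylphenyl on a nitrogen on an aromatic ring. Within the data shown here, no measured pair isolates this change, so no step size is known for it. The step of a number 6.5 percentage points higher from compound 1 to compound 3 (within the scatter) is expected to be small, not clearly beyond the scatter, with a slight upward lean given that compound 2 with its ethyl-bearing ring reaches 31.5%. Compound 3 is therefore estimated at 20%, between 5% and 40%.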

Compound 3, a percentage reported as inhibition, at one concentration (the size of the read-out at that concentration, not a potency): 23%
For compound 3 the middle estimate is 3 percentage points below the measured one; the range from low to high includes it.
By their numbers in this assay, from the lowest: compounds 1, 3 and 2 (each within the scatter of the next, the first and the last beyond it).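

In this assay, 3-ethylphenyl in place of 4-methoxy-3-methylphenyl on a nitrogen on an aromatic ring gives a number 9.5 percentage points higher from compound 1 to compound 3 (within the scatter), the first step read at this position. At this position the loss of the methoxy and methyl pair therefore brings no change in the number beyond the scatter, with the other end of the molecule held constant. No measurement at hand bears on the reason for this result.

Still open, as far as these compounds go, is whether a longer chain than ethyl, or an amine or a carboxylic acid on this ring, would move the read-out beyond the scatter. Also open, from the compounds shown here alone, is whether this step holds with a different group on the far side of the core.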